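Methyl for benzamido on the triazole aryl ring

The compounds below may be only part of what the source reports. "The series", "measured", "known", "first", "only" and "open" are said of these compounds alone.

Measured so far:
compound 1, `COc1cc(/C=C/C(C)=O)ccc1OCc1cn(-c2c(Cl)cccc2Cl)nn1`: 3070 nM
compound 2, `COc1cc(/C=C/C(C)=O)ccc1OCc1cn(-c2ccc(NC(=O)c3ccccc3)cc2)nn1`: 76800 nM

In a functional assay on PC-3 cells (Homo sapiens) for antiproliferative activity, read by MTT assay, with a stated time of 48 h (a higher number here means a weaker inhibitor, a lower number a stronger inhibitor), compound 1 gives 3070 nM, while compound 2 gives 76800 nM. Compound 2 therefore stands at the higher of the two numbers, and the gap to compound 1 lies well beyond the scatter of this assay. Within the data shown here, these two compounds differ in more than one place, so no single step between them can be read.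

Compound 3, `COc1cc(/C=C/C(C)=O)ccc1OCc1cn(-c2ccc(C)cc2)nn1`, differs from compound 2 in one place: methyl in place of benzamido on an aromatic carbon. The account now follows this step. Among the measured compounds shown here, no measured step of this kind exists among the two compounds, so the expectation rests only on the values of compound 1 and compound 2. Compound 3 is expected to give a number below that of compound 2, because compound 2 gives 76800 nM and compound 1 gives 3070 nM with a different aryl substituent, and the move is estimated as a 6.4-fold lower number from compound 2 to compound 3 (0.81 log units; beyond the scatter), a step beyond the scatter. For compound 3 the estimate in this assay is 12000 nM, with a range from 2500 nM to 45000 nM.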

Compound 3, half-maximal inhibitory concentration: 58100 nM
The estimate for compound 3 lay 4.8-fold (0.68 log units) below the measured number; the whole stated range lies below it.
By their numbers in this assay, from the lowest: compound 1; then compounds 3 and 2 (each within the scatter of the next).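

In this assay, the step of a 1.3-fold lower number from compound 2 to compound 3 (0.12 log units; within the scatter) shows that on this aromatic carbon, para to a large group, methyl and benzamido cannot be told apart, although benzamido brings a six-membered aromatic ring and a hydrogen-bond donor that methyl lacks. The large step in this set comes instead from exchanging the whole aryl group on the aromatic nitrogen, with 4-methylphenyl in place of 2,6-dichlorophenyl: a 19-fold higher number from compound 1 to compound 3 (1.28 log units; beyond the scatter). Nothing available explains either result.

The compounds shown leave open whether a small amine, a carboxylic acid or a chloro group on this same carbon would also stay within the scatter of methyl and benzamido. They also cannot separate the part of the aryl exchange that belongs to the two chloro groups from the part that belongs to the methyl, since a phenyl ring carrying a single chloro group does not appear among them.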